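Methyl ester in place of a difluoropropyl amide

A few compounds are considered here, and "the series" means these few. Any claim that something is new, unique, unknown or untested is made for them only; others in the source may bear on it.

Compound 1 `COCCOC(=O)c1cc(N)c(Nc2ccc(C#N)cc2)cc1Oc1c(C)cc(/C=C/C#N)cc1C`: in an ADME assay on a cell-free system (plasma, Homo sapiens) for metabolic stability, read by LC-MS, tested at 10 ug/mL (on this read-out higher numbers stand for a longer-lived compound and lower numbers for a shorter-lived compound), compound 1 gives 62 h.
Compound 2 `CCNC(=O)c1cc(N)c(Nc2ccc(C#N)cc2)cc1Oc1c(C)cc(/C=C/C#N)cc1C`: in this assay compound 2 gives 91 h.
Compound 3 `Cc1cc(/C=C/C#N)cc(C)c1Oc1cc(Nc2ccc(C#N)cc2)c(N)cc1C(=O)NCCC(F)F`: in this assay compound 3 gives 57 h.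

Compound 3 has the lowest of the three numbers, but its gaps to compound 1 and to compound 2 both sit within the usual scatter, so the three compounds cannot be ranked against each other on this read-out.

Compound 4 `COC(=O)c1cc(N)c(Nc2ccc(C#N)cc2)cc1Oc1c(C)cc(/C=C/C#N)cc1C` differs from compound 3 in one place: methoxy in place of (3,3-difluoropropyl)amino on a carbonyl carbon. The measured step that bears most directly on this is the one from an ester to an amide at the same carbonyl carbon, which gave a 1.1-fold lower number from compound 1 to compound 3 (0.04 log units; within the scatter). The two remaining steps, which vary the chain on the amide nitrogen or exchange ester for amide, gave a 1.5-fold higher number from compound 1 to compound 2 (0.17 log units; within the scatter) and a 1.6-fold lower number from compound 2 to compound 3 (0.20 log units; within the scatter). None of the three moved the number beyond the scatter.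

On that basis the expected change in this assay from compound 3 to compound 4 is none beyond the scatter, estimated as a 1.1-fold higher number from compound 3 to compound 4 (0.02 log units; within the scatter). Compound 4 is therefore expected to give about 60 h, with a range from 35 h to 105 h.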

Compound 4, half-life: 89 h
For compound 4 the middle estimate is 1.5-fold (0.17 log units) below the measured one; low and high end bracket the measured number.
By their numbers in this assay, from the lowest: compounds 3, 1, 4 and 2 (each within the scatter of the next).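

In this assay the methoxy group on the carbonyl carbon gives a 1.6-fold higher number from compound 3 to compound 4 (0.19 log units; within the scatter) when it takes the place of (3,3-difluoropropyl)amino, and a 1.0-fold lower number from compound 2 to compound 4 (0.01 log units; within the scatter) when it takes the place of ethylamino. Within the esters, the change from 2-methoxyethoxy to methoxy gives a 1.4-fold higher number from compound 1 to compound 4 (0.16 log units; within the scatter) and so, like the two steps from the amides, stays inside the usual spread of repeat measurements. With a second ester now on the shared core, this position has two esters and two amides, and none of the three new steps separates an ester from an amide, while no measurement beyond these half-lives offers an explanation for that.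

Going by these compounds, all four compounds still carry a carbonyl group at this position with a small or moderate chain on it, so what a free carboxylic acid or an unsubstituted amide would give in this assay stays open. Also open, on these data alone, is whether a much longer chain, or one ending in an amine, would move the number beyond the scatter at all.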